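Moving the Methoxy from 2-Methoxyphenyl to 4-Methoxyphenyl

The source may hold more compounds than are shown below. What is called first, only, known or untested is meant among the compounds shown, and "the series" means these compounds.

In a functional assay on DU-145 cells (Homo sapiens) for inhibition, read by trypan blue exclusion, with a stated time of 96 h (on this read-out lower numbers stand for stronger inhibition of growth and higher numbers for weaker inhibition of growth), compound 3 `COc1ccccc1/C=C(\C(=O)c1ccc(Cl)cc1)S(=O)(=O)c1ccc(Br)cc1` gives 10000 nM, the second highest of three numbers. Compound 1 `Cc1ccc(C)c(/C=C(\C(=O)c2ccc(Cl)cc2)S(=O)(=O)c2ccc(Br)cc2)c1` gives the lowest, 1000 nM, and compound 2 `O=C(/C(=C\c1ccccc1F)S(=O)(=O)c1ccc(Br)cc1)c1ccc(Cl)cc1` gives the highest, 25000 nM. Compound 4 `COc1ccc(/C=C(\C(=O)c2ccc(Cl)cc2)S(=O)(=O)c2ccc(Br)cc2)cc1` carries 4-methoxyphenyl in place of 2-methoxyphenyl on a double-bonded chain carbon bound to a double-bonded chain carbon. For the measured compounds named here, no measured step moves a group in this way, so the evidence is indirect. Changes at this place gave a 25-fold higher number from compound 1 to compound 2 (1.40 log units; beyond the scatter) and a 10-fold higher number from compound 1 to compound 3 (1.00 log units; beyond the scatter), which are sizeable, and a 2.5-fold lower number from compound 2 to compound 3 (0.40 log units; beyond the scatter), which is smaller. These steps show sensitivity here but no direction for this move, so no shift beyond the scatter is expected. The expected change is a 1.7-fold lower number from compound 3 to compound 4 (0.22 log units; within the scatter). For compound 4 the estimated value is 6000 nM, within an expected range of 1500 nM to 25000 nM.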

Compound 4, concentration for 50% growth inhibition: 10000 nM
Compound 4: the middle estimate sits 1.7-fold (0.22 log units) below what was measured, and the stated range covers the measured number.
By their numbers in this assay, from the lowest: compound 1; then compounds 3 and 4 (each within the scatter of the next); then compound 2.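

In this assay, replacing 2-methoxyphenyl with 4-methoxyphenyl gives no change at the digits printed from compound 3 to compound 4 (within the scatter), so at this place the two methoxyphenyl groups cannot be told apart. The 4-methoxyphenyl group also stands where 2-methoxyphenyl stood relative to the other two groups, with a 2.5-fold lower number from compound 2 to compound 4 (0.40 log units; beyond the scatter) and a 10-fold higher number from compound 1 to compound 4 (1.00 log units; beyond the scatter). Nothing measured here bears on this result. The compounds shown leave open whether 4-hydroxyphenyl or 4-aminophenyl would match 4-methoxyphenyl. They also leave open whether 4-methylphenyl would fall nearer 4-methoxyphenyl or 2,5-dimethylphenyl.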